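Swapping the Chain End of a Weak Sulfonamide Inhibitor

The source may report more compounds than this note shows. Statements on the series, on what has been measured and on what is new or still open speak of the compounds shown alone.

Compound 1 `O=S(=O)(NCCNC(=S)Nc1ccc(Cl)cc1)c1ccc(-c2ccccc2OCc2ccccc2)s1` was tested in a functional assay on HL-60 cells (Homo sapiens) for inhibition, read by CCK-8 assay, with a stated time of 48 h; a lower number here means a stronger inhibitor, a higher number a weaker inhibitor. In that assay compound 1 gives only > 50000 nM, which is a limit of the assay rather than a measured number, as the limit of > 50000 nM in this assay, at which 1 of the 2 values shown sits, records. Compound 2 `COc1ccc(NC(=O)NCCNS(=O)(=O)c2sccc2-c2ccc(C)cc2Oc2ccc(O)c(O)c2)cc1` differs from compound 1 in several places at once; in this assay compound 2 gives 6100 nM. Compound 3 `COc1cccc(NC(=O)NCCNS(=O)(=O)c2ccc(-c3ccccc3OCc3ccccc3)s2)c1` is a closer relative of compound 1. The change is a group of 11 heavy atoms (8 carbon, 1 nitrogen, 2 oxygen; one six-membered aromatic ring of carbon only) in place of a group of 10 heavy atoms (7 carbon, 1 nitrogen, 1 sulfur, 1 chlorine; one six-membered aromatic ring of carbon only), on an amine nitrogen, so the (3-methoxyphenyl)carbamoyl group now sits on the amine nitrogen. Among the measured compounds shown here, no measured pair shows what this exchange alone does. Since compound 1 stands only at a limit, the step from compound 1 to compound 3 cannot be read from the data, and a step of an at least 1.6-fold lower number from compound 1 to compound 3 (0.22 log units; that floor lies within the scatter) is expected, likely modest. Compound 3 is estimated at 30000 nM, within a range from 8000 nM to 100000 nM, and the assay may again return only a limit.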

Compound 3, half-maximal inhibitory concentration: 1700 nM
Compound 3: middle estimate off by 18-fold (1.25 log units), on the high side, outside the stated range (below it).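

Among the compounds shown here, exchanging the group on this amine nitrogen for (3-methoxyphenyl)carbamoyl, with the rest of compound 1 unchanged, is the first change here that can be read on its own: in this assay it gives an at least 29-fold lower number from compound 1 to compound 3 (1.46 log units; beyond the scatter) for this one exchange. This amine nitrogen is therefore a place where the choice of group matters greatly for the read-out on these cells. The printed step is only a floor, and the true step may be larger, since compound 1 rests on a limit: the limit of > 50000 nM in this assay, at which 1 of the 3 values shown sits.

The exchange replaces the sulfur and the chlorine of the old group together, so the compounds shown do not tell which of the two changes carries the step. On these data alone, whether a plain acetyl group on the same nitrogen, or a carboxylic acid on the ring of the new group, would keep this activity also stays open.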